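A Fluoro Substituent on the Ring of Compound 2

The source may report more compounds than this note shows. Statements on the series, on what has been measured and on what is new or still open speak of the compounds shown alone.

Compound 1 `Nc1oncc1-c1ccsc1`: 28 nM
Compound 2 `Nc1oncc1-n1cccn1`: 290 nM
Compound 3 `Cc1ccn(-c2cnoc2N)n1`: 1600 nM

In an assay on isolated protein for inhibition of Tryptophan 2,3-dioxygenase (Homo sapiens), read by fluorescence and mass spectrometry, with stated times of 5 min and 15 min (a higher number here means a weaker inhibitor, a lower number a stronger inhibitor), compound 2 stands second highest of the three numbers; compound 1 is the furthest from it, with a lower number, and compound 3 the nearest, with a higher one. Compound 4 `Nc1oncc1-n1cc(F)cn1` differs from compound 2 in one place: fluoro in place of hydrogen on an aromatic carbon. Among the measured compounds shown here, the only measured step that bears on it is a 5.5-fold higher number from compound 2 to compound 3 (0.74 log units; beyond the scatter), where a single heavy atom entering that same five-membered aromatic ring with 2 nitrogen weakened inhibition modestly. Fluoro is likewise a single heavy atom, so a small weakening, or none beyond the scatter, is expected, giving a 1.6-fold higher number from compound 2 to compound 4 (0.19 log units; within the scatter). Compound 4 is therefore estimated at 450 nM, with a range of 150 nM to 1300 nM.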

Compound 4, half-maximal inhibitory concentration: 340 nM
Compound 4: the middle estimate sits 1.3-fold (0.12 log units) above what was measured; low and high end bracket the measured number.
By their numbers in this assay, from the lowest: compound 1; then compounds 2 and 4 (each within the scatter of the next); then compound 3.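

In this assay, among the compounds shown here, fluoro in place of hydrogen on this aromatic carbon gives a result within the scatter (a 1.2-fold higher number from compound 2 to compound 4 (0.07 log units; within the scatter)), so a single heavy atom on the five-membered aromatic ring with 2 nitrogen does not always weaken inhibition, as the one earlier step on that ring (a 5.5-fold higher number from compound 2 to compound 3 (0.74 log units; beyond the scatter)) might have suggested. Nothing available explains this result.

As far as these compounds go, it remains open whether a larger group on this same carbon, such as an amine, a methoxy group or a carboxylic acid, would leave the number just as unchanged. From the compounds shown here alone, whether fluoro would behave the same way on the other ring carbons also remains open.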